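Chloro Added to the Biaryl Tail of an Amide

The source may hold more compounds than are shown below. What is called first, only, known or untested is meant among the compounds shown, and "the series" means these compounds.

In a functional assay on A549 cells (Homo sapiens) for cytotoxicity, read by MTT assay, with a stated time of 72 h (on this read-out lower numbers stand for stronger inhibition and higher numbers for weaker inhibition), the measured compounds are: compound 1 (`Cc1cccc(-c2ccnc(C(=O)Nc3ccc(Oc4ccnc5[nH]ccc45)cc3)c2)c1`), 7010 nM; compound 2 (`O=C(Nc1ccc(Oc2ccnc3[nH]ccc23)c(F)c1)c1ccc(-c2ccccc2)cn1`), 1250 nM.

Compound 2 gives the lowest of the two numbers in this assay; compound 1 stands at a higher number, a gap beyond the scatter. Compound 3 (`O=C(Nc1ccc(Oc2ccnc3[nH]ccc23)c(F)c1)c1ccc(-c2ccc(Cl)cc2)cn1`) differs from compound 2 only by chloro in place of hydrogen on an aromatic carbon. No measured pair among these compounds shows this kind of change, so nothing here sets its size. A step of a 1.3-fold lower number from compound 2 to compound 3 (0.10 log units; within the scatter) is expected from this change, small and likely within the scatter. For compound 3 the value in this assay is estimated at 1000 nM, within a range from 350 nM to 3000 nM.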

Compound 3, half-maximal inhibitory concentration: 10000 nM
Compound 3: middle estimate off by 10-fold (1.00 log units), on the low side, outside the stated range (above it).
By their numbers in this assay, from the lowest: compound 2; then compounds 1 and 3 (each within the scatter of the next).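

Chloro on this aromatic carbon, para to a large group, does not leave the number in place: in this assay the change from phenyl to 4-chlorophenyl brings an 8.0-fold higher number from compound 2 to compound 3 (0.90 log units; beyond the scatter) and so marks this position as sensitive to a single chlorine. The earlier compounds shown here held no pair that could show this. Nothing measured here gives a reason for the step. Going by these compounds, whether fluoro, methoxy or an amine at this place would raise the number in the same way stays open, as does the effect of chloro on another carbon of this ring.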